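A few compounds are considered here, and "the series" means these few. Any claim that something is new, unique, unknown or untested is made for them only; others in the source may bear on it.

In a functional assay on MCF7 cells (Homo sapiens) for antiproliferative activity (on this read-out higher numbers stand for weaker inhibition of growth and lower numbers for stronger inhibition of growth), so far:
- Compound 1 `COc1ccc(-c2nc3cc(F)ccc3s2)cc1C` gives 48 nM
- Compound 2 `CCOc1cc(-c2nc3cc(F)ccc3s2)ccc1OC` gives 80 nM

Compound 2 cannot be told apart from compound 1 on these numbers. Going by the values given here, the only measured step is a 1.7-fold higher number from compound 1 to compound 2 (0.22 log units; within the scatter) and so the two values sit together.

Compound 3 `CCOc1ccc(-c2nc3cc(F)ccc3s2)cc1OCC` differs from compound 2 by methyl in place of hydrogen on a saturated chain carbon bound to an oxygen on an aromatic ring and this is methyl in place of hydrogen on a saturated chain carbon bound to an oxygen on an aromatic ring, which turns methoxy into ethoxy. The measured step also brought in an ethoxy, but it replaced a different group, so it is only a loose guide. With that single guide, no shift beyond the scatter is expected in this assay and the estimated step is a 1.3-fold higher number from compound 2 to compound 3 (0.10 log units; within the scatter) in size. The estimate for compound 3 is 100 nM with an expected range from 40 nM to 260 nM on this read-out.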

Compound 3, concentration for 50% growth inhibition: 0.7 nM
Estimate against measurement, compound 3: 140-fold (2.15 log units) above; the whole stated range lies above it.
By their numbers in this assay, from the lowest: compound 3; then compounds 1 and 2 (each within the scatter of the next).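

In this assay the change of methoxy into ethoxy, methyl in place of hydrogen on a saturated chain carbon bound to an oxygen on an aromatic ring, gives a 110-fold lower number from compound 2 to compound 3 (2.06 log units; beyond the scatter) and so shows that one added methyl at this place can strengthen growth inhibition greatly. The earlier step also brought in an ethoxy but stayed within the scatter, so an ethoxy does not give the same result in every change: compound 3 carries two ethoxy groups, whereas compound 2 carries one ethoxy and one methoxy. Nothing in the available data explains why this single methyl makes so large a difference.

On these data alone, whether a longer chain, such as propoxy, would keep this strong inhibition remains open. So does the outcome of placing an amine or a carboxylic acid at the end of this chain.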